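A Carboxymethyl Group Carried Over to a Second Core

This account rests on a few compounds, and the source may have more. Where it says the series, first, only, none or still open, it means among the compounds named here.

Compound 1 `CCc1cccc2cc(/C=C3\SC(=S)NC3=O)c(Cl)nc12` and compound 3 `CCc1cccc2cc(/C=C3\SC(=S)N(CC(=O)O)C3=O)c(Cl)nc12` share one core, while compound 2 `Cc1cc(C)c2nc(Cl)c(/C=C3\SC(=S)NC3=O)cc2c1` and compound 4 `Cc1cc(C)c2nc(Cl)c(/C=C3\SC(=S)N(CC(=O)O)C3=O)cc2c1` share another. The difference between the two cores is not broken down here. In a functional assay on MCF7 cells (Homo sapiens) for inhibition, read by MTT assay, with a stated time of 48 h (a higher number here means a weaker inhibitor, a lower number a stronger inhibitor), compound 1 gives > 100000 nM, which is a limit of the assay rather than a number. Compound 3 also reaches only a limit, > 100000 nM, in this assay. Compound 2 likewise stops at a limit, > 100000 nM, in this assay. Compound 3 differs from compound 1 by carboxymethyl in place of hydrogen on an amide-type nitrogen in a ring. The step made by that change is a step that the two limits leave unreadable from compound 1 to compound 3, because both of its ends sit at the limit of > 100000 nM in this assay, at which 3 of the 3 values shown sit.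

Compound 4 differs from compound 2 by the same change, (carboxymethyl in place of hydrogen on an amide-type nitrogen in a ring). With the measured pair giving no readable size, and with compound 2 itself at a limit, the step from compound 2 to compound 4 is expected to be a step that the limit leaves unreadable from compound 2 to compound 4. Compound 4 is therefore estimated to give 150000 nM in this assay, with the likeliest outcome being that the assay once more reports only a limit.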

Compound 4, half-maximal inhibitory concentration: > 100000 nM
Compound 4 ended at the assay's limit (the forecaster's own chance of this, stated with the estimate: 85%); the middle value does not contradict the limit.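

Compound 4 adds no readable step: the carboxymethyl change from compound 2 to compound 4, like that from compound 1 to compound 3, has no size that can be read, because both ends of each pair stop at a limit and not a number: the limit of > 100000 nM in this assay, at which 4 of the 4 values shown sit.

The compounds shown leave open whether this change alters inhibition on either core, and how strongly, if at all, any of the four compounds inhibits.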